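The source may hold more compounds than are shown below. What is called first, only, known or untested is meant among the compounds shown, and "the series" means these compounds.

Values in a functional assay on HT-29 cells (Homo sapiens) for antiproliferative activity, read by MTT assay, with a stated time of 72 h (on this read-out higher numbers stand for weaker inhibition and lower numbers for stronger inhibition), so far
compound 1 `C=CC(=O)Nc1nc(-c2ccccc2)cs1` gives 6600 nM
compound 2 `C=CC(=O)Nc1nc(-c2ccc(C)cc2)cs1` gives 16100 nM
compound 3 `C=CC(=O)Nc1nc(-c2ccccc2O)cs1` gives 16200 nM

Compound 1 holds the lowest number of the three, which makes it the strongest inhibitor in this small set. Both measured steps start from it. Methyl in place of hydrogen on an aromatic carbon gives a 2.4-fold higher number from compound 1 to compound 2 (0.39 log units; beyond the scatter) as its result, and hydroxy in place of hydrogen on an aromatic carbon gives a 2.5-fold higher number from compound 1 to compound 3 (0.39 log units; beyond the scatter) as its result. Both steps are modest and both go the same way.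

Compound 4 `C=CC(=O)N(Cc1ccccc1)c1nc(-c2ccccc2)cs1` differs from compound 1 by benzyl in place of hydrogen on an amide-type nitrogen in one place, with benzyl in place of hydrogen on an amide-type nitrogen. Among the measured compounds shown here, no measured compound carries a change at this nitrogen, so the two steps bear on it only indirectly and the range has to stay wide. For the measured compounds named here, with a 2.4-fold higher number from compound 1 to compound 2 (0.39 log units; beyond the scatter) and a 2.5-fold higher number from compound 1 to compound 3 (0.39 log units; beyond the scatter) as the only guide, a modest step toward a higher number is expected in this assay for this change. The estimate amounts to a 2.1-fold higher number from compound 1 to compound 4 (0.33 log units; beyond the scatter) as the expected step. For compound 4 the estimated value is 14000 nM with an expected range from 4500 nM to 45000 nM in this assay.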

Compound 4, half-maximal inhibitory concentration: > 30000 nM
Compound 4: a limit, no number; the forecaster's own chance of this, stated with the estimate: 10%; middle value at least 2.1-fold (0.33 log units) from the limit.
By their numbers in this assay, from the lowest: compound 1; then compounds 2 and 3 (each within the scatter of the next). At a limit, above all of these: compound 4.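

Compound 4 yields only a limit, not a number, in this assay: the limit of > 30000 nM in this assay, at which 1 of the 4 values shown sits. Among the compounds shown here, this is the first reading at the amide-type nitrogen, where benzyl in place of hydrogen gives an at least 4.5-fold higher number from compound 1 to compound 4 (0.65 log units; beyond the scatter), so the change moves in the same direction as the two changes on an aromatic carbon but its full size cannot be read from a limit. For the compounds shown here, the three compounds with numbers in this set all keep the amide hydrogen, while compound 4, the only one that carries a group on that nitrogen, is the only one that ends at the limit.

With benzyl as the only group on this nitrogen, the compounds shown leave open whether the loss of the amide hydrogen or the benzyl group itself goes with the result, and a methyl group there would begin to separate the two. They also leave open how a longer chain ending in an amine or a carboxylic acid would read at this nitrogen, and whether any such group would return a number rather than a limit.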